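Amide substituent variation on a shared core: inhibition read-out

The source may report more compounds than this note shows. Statements on the series, on what has been measured and on what is new or still open speak of the compounds shown alone.

Measured compounds:
compound 1 `CN(C)CCNC(=O)c1c(O)c2cccnc2n(-c2ccccc2)c1=O`, 18.4%
compound 2 `O=C(Nc1cnccn1)c1c(O)c2cccnc2n(-c2ccccc2)c1=O`, 21.2%

In a functional assay on the whole organism for inhibition, with Rattus norvegicus as the target, read by cytopathic effect and paw edema, at a dose of 100 mg/kg by the oral route (on this read-out lower numbers stand for less inhibition and higher numbers for more inhibition at the one dose given (going by the name of the read-out)), compound 1 gives 18.4% and compound 2 gives 21.2%. The two values lie within the usual scatter of each other, so compound 2 cannot be set apart from compound 1 on these numbers. For the measured compounds named here, the single measured step, a number 2.8 percentage points higher from compound 1 to compound 2 (within the scatter), exchanges the group on the amide-type nitrogen and stays within the scatter.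

Compound 3 `O=C(NCc1cccnc1)c1c(O)c2cccnc2n(-c2ccccc2)c1=O` has not been measured. It differs from compound 2 by (pyridin-3-yl)methyl in place of pyrazin-2-yl on an amide-type nitrogen. Going by the values given here, the only step that bears on this change is a number 2.8 percentage points higher from compound 1 to compound 2 (within the scatter), itself a change at the amide-type nitrogen that did not exceed the scatter; from it no step beyond the scatter is expected for the new group either. Compound 3 is therefore expected to show a number 1.2 percentage points lower from compound 2 to compound 3 (within the scatter) in this assay. The estimate for compound 3 in this assay is 20%, with an expected range from 5% to 38%.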

Compound 3, a percentage reported as inhibition, in the whole organism at one dose (the size of the read-out at that dose, not a potency): 14.7%
The estimate for compound 3 lay 5.3 percentage points above the measured number; the measured number falls inside the stated range.
By their numbers in this assay, from the lowest: compounds 3, 1 and 2 (each within the scatter of the next).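

Exchanging pyrazin-2-yl for (pyridin-3-yl)methyl on the amide-type nitrogen gives a number 6.5 percentage points lower from compound 2 to compound 3 (within the scatter) in this assay, and pyridin-3-yl in place of (dimethylamino)methyl on the saturated chain carbon gives a number 3.7 percentage points lower from compound 1 to compound 3 (within the scatter). The position has now carried an aromatic ring bound directly to the nitrogen, an aromatic ring held on a chain carbon and an open chain ending in dimethylamino, and all three stand within the scatter of one another, so adding the chain carbon to a ring-bearing group has not set a compound apart here. Nothing on hand gives a reason for these small differences.

On these data alone, whether any group on this nitrogen can move the read-out beyond the scatter remains open, for example a carboxylic acid, a piperidine or a longer chain carrying the pyridin-3-yl ring. Also open, as far as these compounds go, is whether these compounds would separate at other doses.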